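Pyridin-3-yl in place of pyridin-2-yl on the shared core

The source may hold more compounds than are shown below. What is called first, only, known or untested is meant among the compounds shown, and "the series" means these compounds.

Of the compounds shown here, three on one shared core have so far been measured in a functional assay on MCF7 cells (Homo sapiens) for cytotoxicity, read by MTT assay, with a stated time of 48 h (on this read-out higher numbers stand for weaker inhibition and lower numbers for stronger inhibition), with different aromatic groups. Compound 1 (`Cc1ccc(-c2nnc(SCCn3c([N+](=O)[O-])cnc3C)o2)cc1`), with 4-methylphenyl, gives 15500 nM here, compound 2 (`Cc1ncc([N+](=O)[O-])n1CCSc1nnc(-c2ccccc2N)o1`), with 2-aminophenyl, gives 20100 nM here, and compound 3 (`Cc1ncc([N+](=O)[O-])n1CCSc1nnc(-c2ccccn2)o1`), with pyridin-2-yl, gives 39100 nM on the same read-out. Compound 3 thus stands on the weaker side of compound 1, beyond the scatter, while it lies within the scatter of compound 2.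

The step to compound 4 (`Cc1ncc([N+](=O)[O-])n1CCSc1nnc(-c2cccnc2)o1`) puts pyridin-3-yl in place of pyridin-2-yl on an aromatic carbon, so the same atoms are joined differently. For the measured compounds named here, no measured pair compares two pyridinyl groups, and the evidence is therefore indirect. Exchanges at this place have moved the number little so far: a 1.3-fold higher number from compound 1 to compound 2 (0.11 log units; within the scatter) and a 1.9-fold higher number from compound 2 to compound 3 (0.29 log units; within the scatter) are the two smaller steps, and the largest, a 2.5-fold higher number from compound 1 to compound 3 (0.40 log units; beyond the scatter), is only modest. In this assay the expected result is a 1.3-fold lower number from compound 3 to compound 4 (0.12 log units; within the scatter) and thus no step beyond the scatter in either direction. Compound 4 is estimated at 30000 nM with an expected range from 14000 nM to 60000 nM in this assay for now.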

Compound 4, half-maximal inhibitory concentration: 28700 nM
Estimate against measurement, compound 4: 1.0-fold (0.02 log units) above, within the range that was stated.
By their numbers in this assay, from the lowest: compounds 1, 2, 4 and 3 (each within the scatter of the next, the first and the last beyond it).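

In this assay, for the compounds shown here, this is the first direct comparison of two pyridinyl groups on this aromatic carbon of the shared core, and a 1.4-fold lower number from compound 3 to compound 4 (0.13 log units; within the scatter) shows that exchanging pyridin-2-yl for pyridin-3-yl, with the same atoms joined differently, gives no difference that can be read in this pair. Compound 4 also stays close to both phenyl-bearing compounds, with a 1.4-fold higher number from compound 2 to compound 4 (0.15 log units; within the scatter) and a 1.9-fold higher number from compound 1 to compound 4 (0.27 log units; within the scatter) both printed as within the scatter, whereas compound 3 lies beyond the scatter of compound 1, so only pyridin-2-yl, and not pyridin-3-yl, is separated from 4-methylphenyl on this read-out. Nothing at hand accounts for these values or for that contrast.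

The compounds shown leave open whether pyridin-4-yl, unsubstituted phenyl, or a phenyl bearing a carboxylic acid or a longer chain would stay within this same span of values or move clearly outside it. They also leave open whether the close agreement of compound 4 with the other three would hold on cells other than those of this one assay.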